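Chain-end change in a long-chain anilide ACAT inhibitor

A few compounds are considered here, and "the series" means these few. Any claim that something is new, unique, unknown or untested is made for them only; others in the source may bear on it.

The measured compounds in a functional assay on microsomes from intestine for inhibition of acyl-CoA:cholesterol acyltransferase (Oryctolagus cuniculus); on this read-out higher numbers stand for weaker inhibition and lower numbers for stronger inhibition:
Compound 1, `CCCCCCCCCCCC(=O)C(C)(C)C(=O)Nc1c(OC)cc(OC)cc1OC`, gives 370 nM.
Compound 2, `CC(C)c1cccc(C(C)C)c1NC(=O)CC(=O)CCCCCCCCCCOC1CCCCO1`, gives 57 nM.
Compound 3, `CC(C)c1cccc(C(C)C)c1NC(=O)CC(=O)CCCCCCCCCCO`, gives 230 nM.

Among the three numbers, compound 2 has the lowest value in this assay, with compound 3 nearest and compound 1 furthest from it. Compound 4, `CCCCCCCCCCCCCC(=O)CC(=O)Nc1c(C(C)C)cccc1C(C)C`, has not yet been measured. It differs from compound 2 in one place: propyl in place of (oxan-2-yl)oxy on a saturated chain carbon, ten or more bonds along the chain from a carbonyl carbon.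

Among the measured compounds shown here, only one measured step touches this position. In the step of a 4.0-fold higher number from compound 2 to compound 3 (0.61 log units; beyond the scatter) the oxan-2-yl is removed and a free hydroxyl remains at the chain end, and the number rises modestly. For the measured compounds named here, compound 4 goes further, removing the oxygen as well and extending the carbon chain by propyl; the data hold no step of exactly this kind, and compound 1 carries a different core, so its value cannot be set beside compound 2 directly. Compound 4 is therefore expected to stay in the region of compound 2, with a step of a 1.4-fold higher number from compound 2 to compound 4 (0.15 log units; within the scatter) not beyond the scatter, and its estimated value in this assay is 80 nM, within a range from 25 nM to 250 nM.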

Compound 4, half-maximal inhibitory concentration: 6 nM
Compound 4: the middle estimate sits 13-fold (1.12 log units) above what was measured; measured number below the stated range.
By their numbers in this assay, from the lowest: compound 4; then compound 2; then compounds 3 and 1 (each within the scatter of the next).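

In this assay the chain end proves to be a position where the number moves strongly, and the all-carbon end gives a lower number than either oxygen-bearing end: propyl in place of (oxan-2-yl)oxy gives a large drop (a 9.5-fold lower number from compound 2 to compound 4 (0.98 log units; beyond the scatter)), and propyl in place of hydroxy gives a still larger one (a 38-fold lower number from compound 3 to compound 4 (1.58 log units; beyond the scatter)). The earlier step (a 4.0-fold higher number from compound 2 to compound 3 (0.61 log units; beyond the scatter)) compared only two oxygen-bearing ends and could be read as the number rising as the group on the chain end gets smaller, but compound 4 goes against that reading, since propyl is smaller than (oxan-2-yl)oxy and yet gives the lower number. No measurement shown here accounts for this difference.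

The compounds shown leave open whether the low number belongs to the all-carbon end as such or to this chain length, which a shorter or longer alkyl chain would test. They also leave open how an amine or a carboxylic acid at the chain end would compare, and whether the same change would hold on the core of compound 1.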